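The source may hold more compounds than are shown below. What is called first, only, known or untested is meant among the compounds shown, and "the series" means these compounds.

Measured so far in a functional assay on HepG2 cells (Homo sapiens) for cytotoxicity, read by MTT assay, with a stated time of 72 h; a lower number here means a stronger inhibitor, a higher number a weaker inhibitor:
compound 1, `CNC(=O)c1cc(Oc2ccc(C(=O)/C=C/c3cccc([N+](=O)[O-])c3)cc2)ccn1`, gives > 50000 nM, which is a limit of the assay.
compound 2, `CNC(=O)c1cc(Oc2ccc(/C=C/C(=O)c3ccc(Cl)cc3)cc2)ccn1`, gives 36600 nM.
compound 3, `CNC(=O)c1cc(Oc2ccc(C(=O)/C=C/c3ccc(Cl)cc3Cl)cc2)ccn1`, gives 11700 nM.

Compound 3 stands lowest of the two numbers read in this assay. Compound 2 is its nearest neighbour, with a higher number that lies beyond the scatter. Compound 1 contributes only a limit, (the limit of > 50000 nM in this assay, at which 1 of the 3 values shown sits). For the measured compounds named here, the one step between compounds differing in a single place runs from compound 1 to compound 3: an at least 4.2-fold lower number from compound 1 to compound 3 (0.63 log units; beyond the scatter). It shows that the aryl group on the double-bonded chain carbon bound to a double-bonded chain carbon moves the number by at least a modest amount.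

Compound 4, `CNC(=O)c1cc(Oc2ccc(C(=O)/C=C/c3ccccc3)cc2)ccn1`, is not yet measured. Its change from compound 3 is phenyl in place of 2,4-dichlorophenyl on a double-bonded chain carbon bound to a double-bonded chain carbon. The step from compound 1 to compound 3 concerns the same position but a different leaving group, so it bears on compound 4 only by showing the position is sensitive. Compound 2 differs from compound 3 in more than one place, so only its value is taken, and it sits higher than compound 3. For compound 4 a step up is expected: a 2.6-fold higher number from compound 3 to compound 4 (0.41 log units; beyond the scatter). Compound 4 is estimated at 30000 nM, between 12000 nM and 75000 nM.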

Compound 4, half-maximal inhibitory concentration: 6640 nM
Compound 4: middle estimate off by 4.5-fold (0.65 log units), on the high side; measured number below the stated range.
By their numbers in this assay, from the lowest: compounds 4 and 3 (each within the scatter of the next); then compound 2. At a limit, above all of these: compound 1.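

In this assay, phenyl in place of 2,4-dichlorophenyl on a double-bonded chain carbon bound to a double-bonded chain carbon gives a 1.8-fold lower number from compound 3 to compound 4 (0.25 log units; within the scatter), so the two chlorine atoms make no readable difference at this position. The sensitivity suggested earlier now narrows to the nitro group of compound 1: hydrogen in place of nitro on an aromatic carbon gives an at least 7.5-fold lower number from compound 1 to compound 4 (0.87 log units; beyond the scatter), and among the three compounds that differ only in this aryl group, only the 3-nitrophenyl stands apart from the other two. Compound 1 stands at a limit of the assay, so the size of this step is a bound and not a measured gap: the limit of > 50000 nM in this assay, at which 1 of the 4 values shown sits.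

The compounds shown leave open whether the separation belongs to the nitro group itself or would also appear with an amine or a carboxylic acid on the same aromatic carbon. They also leave open how a single chlorine on this phenyl ring would read, and whether a longer chain between the carbonyl and the aryl group would move the number at all.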